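Hydrazone aryl exchange: pyridin-4-yl back to hydroxyphenyl

A few compounds are considered here, and "the series" means these few. Any claim that something is new, unique, unknown or untested is made for them only; others in the source may bear on it.

Compound 2 `Cc1c(C(=O)N/N=C\c2ccncc2)oc2cccc(O)c12` sits at the upper edge of the numbers shown. In a functional assay on PC-3 cells (Homo sapiens) for inhibition (on this read-out lower numbers stand for stronger inhibition and higher numbers for weaker inhibition), compound 2 gives >= 40000 nM, which is a limit of the assay and not a number (the limit of >= 40000 nM in this assay, at which 1 of the 2 values shown sits). Compound 1 `Cc1c(C(=O)N/N=C\c2c(O)cccc2Cl)oc2cccc(O)c12` gives 18700 nM in this assay, and the step of an at least 2.1-fold higher number from compound 1 to compound 2 (0.33 log units; beyond the scatter) is the only measured one that bears here. Compound 3 `Cc1c(C(=O)N/N=C\c2ccc(Br)cc2O)oc2cccc(O)c12` carries 4-bromo-2-hydroxyphenyl in place of pyridin-4-yl on a carbon with a double bond to nitrogen; a 4-bromo-2-hydroxyphenyl returns in place of the pyridin-4-yl, the reverse direction of the measured step, so a lower number is expected in this assay. Compound 3 is expected near 20000 nM (range 8000 nM to 50000 nM). The step of an at least 2.0-fold lower number from compound 2 to compound 3 (0.30 log units; that floor lies within the scatter) is the estimated outcome.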

Compound 3, half-maximal inhibitory concentration: 2050 nM
The estimate for compound 3 lay 9.8-fold (0.99 log units) above the measured number; the whole stated range lies above it.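

On the carbon with a double bond to nitrogen, the choice of aryl group moves the number in this assay much further than the first pair showed, with an at least 19-fold lower number from compound 2 to compound 3 (1.29 log units; beyond the scatter). The value of compound 2 is a limit and not a number: the limit of >= 40000 nM in this assay, at which 1 of the 3 values shown sits.

A hydroxyphenyl group alone does not settle the outcome, as 4-bromo-2-hydroxyphenyl and 2-chloro-6-hydroxyphenyl stand apart, with a 9.1-fold lower number from compound 1 to compound 3 (0.96 log units; beyond the scatter).

Still open, on these data alone, is how much of this follows the bromine, the hydroxyl or the arrangement of the two on the ring. A 4-bromophenyl and a plain 2-hydroxyphenyl group at this place would help separate them.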